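The source may report more compounds than this note shows. Statements on the series, on what has been measured and on what is new or still open speak of the compounds shown alone.

Measured compounds:
Compound 1 `C/C(=C\CC/C(C)=C/CC[C@@H]1[C@@]2(C)CCC(=O)C(C)(C)[C@H]2CC[C@@]1(C)O)CC/C=C(\C)C(=O)OCc1cn(-c2cccc(O)c2)nn1` gives 42800 nM.
Compound 2 `C/C(=C\CC/C(C)=C/CC[C@@H]1[C@@]2(C)CCC(=O)C(C)(C)[C@H]2CC[C@@]1(C)O)CC/C=C(\C)C(=O)OCc1cn(-c2cccc(Cl)c2)nn1` gives 147000 nM.
Compound 3 `C/C(=C\CC/C(C)=C/CC[C@@H]1[C@@]2(C)CCC(=O)C(C)(C)[C@H]2CC[C@@]1(C)O)CC/C=C(\C)C(=O)OCc1cn(-c2ccc(F)cc2)nn1` reaches only the limit of the assay, > 150000 nM.

All three share one core and differ only in the aromatic group on the triazole nitrogen. In a functional assay on A549 cells (Homo sapiens) for antiproliferative activity, read by MTT assay, with a stated time of 48 h (a higher number here means a weaker inhibitor, a lower number a stronger inhibitor), compound 1 gives 42800 nM, the lowest of the two numbers that are actual values; its nearest neighbour is compound 2, with a 3.4-fold higher number from compound 1 to compound 2 (0.54 log units; beyond the scatter). Compound 3 gives no number at all, only (the limit of > 150000 nM in this assay, at which 1 of the 3 values shown sits).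

Compound 4 `C/C(=C\CC/C(C)=C/CC[C@@H]1[C@@]2(C)CCC(=O)C(C)(C)[C@H]2CC[C@@]1(C)O)CC/C=C(\C)C(=O)OCc1cn(-c2ccccc2[N+](=O)[O-])nn1` is the unmeasured variant. It differs from compound 1 by 2-nitrophenyl in place of 3-hydroxyphenyl on an aromatic nitrogen.

Two measured steps start from compound 1 and swap out the same 3-hydroxyphenyl group: a 3.4-fold higher number from compound 1 to compound 2 (0.54 log units; beyond the scatter), and an at least 3.5-fold higher number from compound 1 to compound 3 (0.54 log units; beyond the scatter). Both exchanges gave a higher number, that is a weaker inhibitor, and neither replacement kept the hydroxy group. The 2-nitrophenyl group of compound 4 likewise lacks it. A modest rise in this assay is therefore the expectation, with a real chance that only a limit is reported.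

Compound 4 is expected to give about 120000 nM, with a likely range from 40000 nM to 300000 nM. That estimate corresponds to a 2.8-fold higher number from compound 1 to compound 4 (0.45 log units; beyond the scatter).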

Compound 4, half-maximal inhibitory concentration: > 150000 nM
Compound 4 ended at the assay's limit; the forecaster's own chance of this, stated with the estimate: 35%; middle value at least 1.2-fold (0.09 log units) from the limit.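

Swapping the 3-hydroxyphenyl group on the aromatic nitrogen for 2-nitrophenyl gives an at least 3.5-fold higher number from compound 1 to compound 4 (0.54 log units; beyond the scatter) in this assay. This makes three different replacements at this position, each without the hydroxy group and each giving a higher number than compound 1, and none of the compounds shown goes against that pattern; the new one also brings 2 hydrogen-bond acceptors and no donor, so an acceptor-bearing group did not restore the lower number of compound 1. Against the chlorinated analogue the result gives an at least 1.0-fold higher number from compound 2 to compound 4 (0.00 log units; that floor lies within the scatter), so no order can be stated between these two compounds, and the step from compound 3 to compound 4 cannot be read, since both stand at a limit and not at a number: the limit of > 150000 nM in this assay, at which 2 of the 4 values shown sit.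

Among these compounds, what stays open is whether the hydroxy group itself accounts for the lower number of compound 1, since only one hydroxylated aryl group appears here and a methoxyphenyl or an aminophenyl group would test that directly. As far as these compounds go, how far the true value of compound 4 lies past the limit of the assay also remains unknown, as does whether any group at this position can go lower than compound 1.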